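This account rests on a few compounds, and the source may have more. Where it says the series, first, only, none or still open, it means among the compounds named here.

In an ADME assay on HEK293 cells (Homo sapiens) for cytotoxicity, read by MTT assay, with a stated time of 48 h (a higher number here means a weaker inhibitor, a lower number a stronger inhibitor), compound 1 `CN(c1ccc(NC(=O)c2cc(C(F)(F)F)cc(C(F)(F)F)c2)cc1OCc1cccc(C(F)(F)F)c1)S(C)(=O)=O` gives > 500000 nM as a limit of the assay. Compound 2 `CN(c1ccc(NC(=O)c2ccc(C(F)(F)F)cc2C(F)(F)F)cc1OCc1cccc(C(F)(F)F)c1)S(C)(=O)=O` gives > 500000 nM and this too is only a limit. The record so far is the limit of > 500000 nM in this assay, at which 2 of the 2 values shown sit, and it leaves compound 2 without a number of its own. Compound 3 `CN(c1ccc(NC(=O)c2ccc(C(F)(F)F)cc2C(F)(F)F)cc1OCc1ccccc1C(F)(F)F)S(C)(=O)=O` differs from compound 2 in one place 2-(trifluoromethyl)phenyl in place of 3-(trifluoromethyl)phenyl on a saturated chain carbon bound to an oxygen on an aromatic ring on a saturated chain carbon bound to an oxygen on an aromatic ring. No change beyond the scatter is expected in this assay and the estimated step is a number no higher from compound 2 to compound 3 (the limit leaves the size open) in size. Compound 3 is expected near 500000 nM with 200000 nM to 800000 nM as the estimated range.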

Compound 3, half-maximal inhibitory concentration: > 500000 nM
Compound 3 ended at the assay's limit; the forecaster's own chance of this, stated with the estimate: 80%; the middle value sits exactly at the limit.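

In this assay, among these compounds, compound 3 gives > 500000 nM, which is only a limit, so no step from compound 2 to compound 3 can be read. The actual half-maximal inhibitory concentrations of compound 1, compound 2 and compound 3 stay open: the limit of > 500000 nM in this assay, at which 3 of the 3 values shown sit.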